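Ester to aryl ketone on a shared acrylonitrile core

The source may hold more compounds than are shown below. What is called first, only, known or untested is meant among the compounds shown, and "the series" means these compounds.

Measured so far:
Compound 1, `N#C/C(=C\c1c(-c2ccccc2)[nH]c2ccccc12)C(=O)Nc1ccc(Cl)cc1`, gives 1700 nM in a functional assay on MT4 cells (Homo sapiens) for antiproliferative activity, read by MTT assay, with a stated time of 96 h; a higher number here means that more compound is needed for the effect, a lower number that less compound is needed.
Compound 2, `COCCOC(=O)/C(C#N)=C/c1c(-c2ccccc2)[nH]c2ccccc12`, gives 1200 nM in this assay.

Compound 2 holds the lowest of the two numbers in this assay, yet its nearest neighbour is compound 1, and the step of a 1.4-fold lower number from compound 1 to compound 2 (0.15 log units; within the scatter) lies within the scatter, so the two cannot be told apart on these data. Compound 3, `N#C/C(=C\c1c(-c2ccccc2)[nH]c2ccccc12)C(=O)c1ccc(Cl)cc1`, has not been measured. It differs from compound 2 by 4-chlorophenyl in place of 2-methoxyethoxy on a carbonyl carbon. For the measured compounds named here, the only measured step that touches the same carbonyl carbon is the one from compound 1 to compound 2, which swapped a (4-chlorophenyl)amino group for 2-methoxyethoxy and moved the number by a 1.4-fold lower number from compound 1 to compound 2 (0.15 log units; within the scatter), within the scatter. Going by the values given here, the step to compound 3 brings the 4-chlorophenyl ring back, now bound directly to the carbonyl carbon, and no measured pair shows how that direct link behaves. On this basis no step beyond the scatter is expected in this assay, in either direction, and the step of a 1.2-fold higher number from compound 2 to compound 3 (0.07 log units; within the scatter) is the estimate. Compound 3 is therefore expected to give about 1400 nM, in the range 500 nM to 4000 nM.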

Compound 3, half-maximal effective concentration: 400 nM
Compound 3: middle estimate off by 3.5-fold (0.54 log units), on the high side, outside the stated range (below it).
By their numbers in this assay, from the lowest: compound 3; then compounds 2 and 1 (each within the scatter of the next).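

At the carbonyl carbon of the shared core, the earlier pair had shown only a swap that stayed within the scatter, but in this assay the 4-chlorophenyl group bound directly to that carbon gives a 3.0-fold lower number from compound 2 to compound 3 (0.48 log units; beyond the scatter) and also a 4.3-fold lower number from compound 1 to compound 3 (0.63 log units; beyond the scatter) and so separates compound 3 from both earlier compounds. The ring alone does not account for the lower number: compound 1 carries the same 4-chlorophenyl ring through an amino nitrogen, yet it stands within the scatter of compound 2, which has no ring at this place, so in these three compounds the lower number appears only where the ring sits directly on the carbonyl carbon. No measurement at hand says what lies behind this difference.

Going by these compounds, whether the lower number belongs to the 4-chlorophenyl group or to a directly bound ring in general stays open, and a plain phenyl or a 4-methoxyphenyl on this carbonyl carbon would begin to separate the two. On these data alone, it is equally open whether a small group such as methyl, bound directly in the same way, would give a number nearer compound 3 or nearer compound 2.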